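Swapping an Amine for a Sulfonium on an Adenosine Chain

The compounds below may be only part of what the source reports. "The series", "measured", "known", "first", "only" and "open" are said of these compounds alone.

Compound 1, `CN(CCCN)C[C@H]1OC(n2cnc3c(N)ncnc32)[C@H](O)[C@@H]1O`: 60000 nM
Compound 2, `C[S+](C)C[C@H]1O[C@@H](n2cnc3c(N)ncnc32)[C@H](O)[C@@H]1O`: 2000 nM

In an assay for inhibition of S-adenosylmethionine decarboxylase proenzyme (Rattus norvegicus), in the presence of a further agent that is not named here (a higher number here means a weaker inhibitor, a lower number a stronger inhibitor), compound 1 gives 60000 nM, the highest of the two numbers and therefore the weakest inhibitor measured here. Compound 2 gives 2000 nM, a far lower number, beyond the scatter. Compound 3, `C[S+](CCCN)C[C@H]1OC(n2cnc3c(N)ncnc32)[C@H](O)[C@@H]1O`, differs from compound 1 by a group of 6 heavy atoms (4 carbon, 1 nitrogen, 1 sulfur; no ring) in place of a group of 6 heavy atoms (4 carbon, 2 nitrogen; no ring), on a saturated chain carbon bound to a saturated ring carbon. Compound 3 thereby carries a positively charged sulfur on the chain, as compound 2 does. A clear downward step, meaning stronger inhibition, is expected from compound 1 to compound 3, about a 60-fold lower number from compound 1 to compound 3 (1.78 log units; beyond the scatter), because compound 2 gives 2000 nM. For compound 3 the expected value is 1000 nM, within a range from 200 nM to 5000 nM.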

Compound 3, inhibition constant: 3000 nM
Compound 3: the middle estimate sits 3.0-fold (0.48 log units) below what was measured, within the range that was stated.
By their numbers in this assay, from the lowest: compounds 2 and 3 (each within the scatter of the next); then compound 1.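

At this position, on a saturated chain carbon bound to a saturated ring carbon, replacing (3-aminopropyl)(methyl)amino with the sulfur-containing group of net charge +1 gives a 20-fold lower number from compound 1 to compound 3 (1.30 log units; beyond the scatter) in this assay. Among the compounds shown here, this is the first direct comparison to show that inhibition responds to a change at this position while the rest of compound 1 stays the same. Nothing measured here explains the size of this step.

The compounds shown cannot separate the contribution of the sulfur from that of the net charge. From the compounds shown here alone, the effect of a longer chain on the sulfur, or of a carboxylic acid in place of the chain's amine, also remains open.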